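The source may report more compounds than this note shows. Statements on the series, on what has been measured and on what is new or still open speak of the compounds shown alone.

The account begins with compound 1 `COc1ccc(-c2cn(C/C=C3\OC(=O)C(OCc4ccccc4)=C3OCc3ccccc3)nn2)cc1`. In a functional assay on HCT-116 cells (Homo sapiens) for antiproliferative activity, read by MTT assay, with a stated time of 72 h (a higher number here means a weaker inhibitor, a lower number a stronger inhibitor), compound 1 gives > 100000 nM, which is a limit of the assay and not a number; the limit of > 100000 nM in this assay, at which 1 of the 3 values shown sits, shows where that limit lies among the values at hand. Two compounds with a different core are also measured. Compound 2 `O=C1O[C@H]([C@@H](O)Cn2cc(CNS(=O)(=O)c3ccc(Cl)cc3F)nn2)C(OCc2ccccc2)=C1OCc1ccccc1` gives 21600 nM in this assay, and compound 3 `O=C1O[C@H]([C@@H](O)Cn2cc(CCO)nn2)C(OCc2ccccc2)=C1OCc1ccccc1` gives 72700 nM. Within the data shown here, the one step between measured compounds, a 3.4-fold higher number from compound 2 to compound 3 (0.53 log units; beyond the scatter), concerns a hydroxymethyl in place of a ((4-chloro-2-fluorophenyl)sulfonyl)amino on a saturated chain carbon bound to an aromatic carbon, a change that has nothing in common with the one at issue here.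

Compound 4 `O=C1O/C(=C\Cn2cc(-c3ccc(Br)cc3)nn2)C(OCc2ccccc2)=C1OCc1ccccc1` has not yet been measured in this assay. It differs from compound 1 by bromo in place of methoxy on an aromatic carbon. Among the measured compounds shown here, no measured step touches an exchange of this kind, and compound 1 itself stands only at a limit, so there is no measured ground for a shift in either direction. The step that the limit leaves unreadable from compound 1 to compound 4 is therefore expected to fall within the scatter, and a limit is again the likeliest outcome. Compound 4 is estimated at 150000 nM, with a range from 50000 nM to 500000 nM.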

Compound 4, half-maximal inhibitory concentration: > 100000 nM
Compound 4 was reported as a limit; the forecaster's own chance of this, stated with the estimate: 75%; the middle value is on the limit's open side.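

In this assay compound 4 gives > 100000 nM, which is a limit of the assay and not a number. Compound 1 is also reported only as a limit, so no step can be read from compound 1 to compound 4: the limit of > 100000 nM in this assay, at which 2 of the 4 values shown sit.

The compounds shown leave open whether 4-methoxyphenyl and 4-bromophenyl differ at all in this assay.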